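Removing the tert-butoxy from a serine ester side chain

The compounds below may be only part of what the source reports. "The series", "measured", "known", "first", "only" and "open" are said of these compounds alone.

Measured so far in an assay on HEK293 cells for inhibition of Voltage-dependent T-type calcium channel subunit alpha-1H (Homo sapiens), read by patch clamp, using a membrane potential dye; on this read-out lower numbers stand for stronger inhibition and higher numbers for weaker inhibition:
compound 1 `CC[C@H](C)[C@H](NC(=O)N1CCC2(CC1)C(=O)N(c1cccc(F)c1)C2c1ccc(Cl)cc1)C(=O)OC(C)C`: 45 nM
compound 2 `CC[C@H](C)[C@H](NC(=O)N1CCC2(CC1)C(=O)N(c1cccc(F)c1)C2c1ccc(Cl)cc1)C(=O)NC`: 182 nM
compound 3 `COC(=O)[C@H](COC(C)(C)C)NC(=O)N1CCC2(CC1)C(=O)N(c1cccc(F)c1)C2c1ccc(Cl)cc1`: 251 nM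

Compound 3 holds the highest of the three numbers; its distance to compound 2 is within the scatter, while a 5.6-fold higher number from compound 1 to compound 3 (0.75 log units; beyond the scatter) lies beyond it. Compound 4 `COC(=O)[C@H](C)NC(=O)N1CCC2(CC1)C(=O)N(c1cccc(F)c1)C2c1ccc(Cl)cc1` differs from compound 3 by hydrogen in place of tert-butoxy on a saturated chain carbon, two bonds along the chain from an amide-type nitrogen and a carbonyl carbon, the (tert-butoxy)methyl becoming a methyl. Within the data shown here, no measured step removes this group alone. The steps that touch the side chain, a 5.6-fold higher number from compound 1 to compound 3 (0.75 log units; beyond the scatter) and a 1.4-fold higher number from compound 2 to compound 3 (0.14 log units; within the scatter), change the ester or amide at the same time, so they bear on it only loosely; a 4.0-fold higher number from compound 1 to compound 2 (0.61 log units; beyond the scatter) does not concern the chain. Since the fullest side chain, in compound 1, gave the lowest number, a modest rise is expected here, a 2.0-fold higher number from compound 3 to compound 4 (0.30 log units; within the scatter). Compound 4 is estimated at 500 nM, with a range from 150 nM to 1600 nM.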

Compound 4, half-maximal inhibitory concentration: 827 nM
Compound 4: the middle estimate sits 1.7-fold (0.22 log units) below what was measured; low and high end bracket the measured number.
By their numbers in this assay, from the lowest: compound 1; then compounds 2 and 3 (each within the scatter of the next); then compound 4.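

In this assay, among these compounds, taking off the tert-butoxy alone gives a 3.3-fold higher number from compound 3 to compound 4 (0.52 log units; beyond the scatter), the first reading of this saturated chain carbon with nothing else changed, and it lies beyond the scatter. The smaller 1-(methoxycarbonyl)ethyl on the amide-type nitrogen also stands apart from the larger groups, with a 4.5-fold higher number from compound 2 to compound 4 (0.66 log units; beyond the scatter) and an 18-fold higher number from compound 1 to compound 4 (1.26 log units; beyond the scatter). Nothing available accounts for these rises.

Going by these compounds, whether a hydroxyl, an amine or a longer chain such as ethyl on this carbon would bring the number back towards that of compound 3 remains open. So does whether removing the tert-butoxy would have the same effect with an isopropoxy carbonyl in place of the methyl ester.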